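Moving the lactam within the bicyclic amine of a urea agonist

The source may report more compounds than this note shows. Statements on the series, on what has been measured and on what is new or still open speak of the compounds shown alone.

Measured compounds:
compound 1 `CC1CCN(c2nc(C(F)(F)F)ccc2CNC(=O)Nc2cccc3c(=O)[nH]ccc23)CC1` gives 9.59 nM
compound 2 `CC1CCN(c2nc(C(F)(F)F)ccc2CNC(=O)Nc2ccc3cc[nH]c(=O)c3c2)CC1` gives "not active" (no number reported)

In an assay on CHO cells for agonist activity at transient receptor potential cation channel subfamily V member 1 (Homo sapiens) (on this read-out higher numbers stand for an effect only at larger amounts of compound and lower numbers for an effect already at smaller amounts), compound 1 gives 9.59 nM. In this assay compound 2 is recorded as "not active" (no number reported), so no number stands against it and it cannot be placed on the same scale as compound 1. Compound 3 `CC1CCN(c2nc(C(F)(F)F)ccc2CNC(=O)Nc2ccc3ccc(=O)[nH]c3c2)CC1` differs from compound 2 in a group of 11 heavy atoms (9 carbon, 1 nitrogen, 1 oxygen; one six-membered aromatic ring of carbon only, one six-membered aromatic ring with 1 hetero atom) in place of a group of 11 heavy atoms (9 carbon, 1 nitrogen, 1 oxygen; one six-membered aromatic ring of carbon only, one six-membered aromatic ring with 1 hetero atom), on an amide-type nitrogen; the two share every atom and differ only in how the bicyclic amine is joined to the urea. Among the measured compounds shown here, with no measured step between any two compounds, the size of the change from compound 2 to compound 3 in this assay cannot be read from the data; the two measured compounds show that such rearrangements can run from clear activity to none. The estimate for compound 3 is 100 nM, within 10 nM to 2000 nM, with a real chance that only a limit is reported.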

Compound 3, half-maximal effective concentration: "not active" (no number reported)
Compound 3 has no reported number here; no gap can be computed for the estimate.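

In this assay, among the compounds shown here, compound 3 gives "not active" (no number reported) and compound 2 gives "not active" (no number reported) so no step between these two compounds can be read. The compounds shown leave open where compound 2 and compound 3 would stand on a numerical scale. No evidence bears on this result.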